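This account rests on a few compounds, and the source may have more. Where it says the series, first, only, none or still open, it means among the compounds named here.

Of the compounds shown here, three built on one shared core have been measured in an assay on isolated protein for displacement of a labelled ligand from 5-hydroxytryptamine receptor 6 (Homo sapiens); on this read-out lower numbers stand for stronger inhibition and higher numbers for weaker inhibition. Compound 1 `O=C(NC[C@@H]1CCCc2cc(S(=O)(=O)c3cccc(F)c3)ccc21)c1ncc[nH]1` gives 15.9 nM, compound 2 `O=C1CN(C[C@@H]2CCCc3cc(S(=O)(=O)c4cccc(F)c4)ccc32)CCN1` gives 6.31 nM, and compound 3 `O=S(=O)(c1cccc(F)c1)c1ccc2c(c1)CCC[C@H]2CNCCO` gives 0.126 nM, the lowest of the three numbers. Compound 4 `NC(=O)NC[C@@H]1CCCc2cc(S(=O)(=O)c3cccc(F)c3)ccc21` differs from compound 3 in one place: carbamoyl in place of 2-hydroxyethyl on an amine nitrogen. Going by the values given here, two measured steps bear on this change, a 130-fold lower number from compound 1 to compound 3 (2.10 log units; beyond the scatter) and a 50-fold lower number from compound 2 to compound 3 (1.70 log units; beyond the scatter), both large. Compound 1 also carries a carbonyl on that amine nitrogen, and compound 4 returns to such an arrangement. A large rise in number is therefore expected for compound 4, a 79-fold higher number from compound 3 to compound 4 (1.90 log units; beyond the scatter). In this assay compound 4 is estimated at 10 nM, with a range from 2 nM to 50 nM.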

Compound 4, inhibition constant: 0.2 nM
For compound 4 the middle estimate is 50-fold (1.70 log units) above the measured one; measured number below the stated range.
By their numbers in this assay, from the lowest: compounds 3 and 4 (each within the scatter of the next); then compound 2; then compound 1.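

In this assay a carbonyl on the amine nitrogen is compatible with a low number, since carbamoyl and 2-hydroxyethyl cannot be told apart there (a 1.6-fold higher number from compound 3 to compound 4 (0.20 log units; within the scatter)). The high number of compound 1 therefore goes with the 1H-imidazol-2-yl group on that carbonyl carbon, as amino in its place shows (an 80-fold lower number from compound 1 to compound 4 (1.90 log units; beyond the scatter)), and ureido likewise stands well clear of 3-oxopiperazin-1-yl (a 32-fold lower number from compound 2 to compound 4 (1.50 log units; beyond the scatter)). No supporting evidence accounts for these differences. Still open, on these data alone, is how acetyl, or a methyl on the terminal nitrogen of the ureido group, would read on this nitrogen.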